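The source may report more compounds than this note shows. Statements on the series, on what has been measured and on what is new or still open speak of the compounds shown alone.

Measured so far:
compound 1 `COc1ccc(N2CCN([C@@H]3CN[C@H](C(=O)N4CCSC4)C3)CC2)cc1` — 16.9 nM
compound 2 `O=C([C@@H]1C[C@H](N2CCC(c3ccccc3)CC2)CN1)N1CCSC1` — 9.6 nM
compound 3 `O=C([C@@H]1C[C@H](N2CCCN(c3ccc([N+](=O)[O-])cc3)CC2)CN1)N1CCSC1` — 2.9 nM

In an assay on a cell-free system (plasma) for inhibition of Dipeptidyl peptidase 4 (Rattus norvegicus), read by fluorescence (on this read-out higher numbers stand for weaker inhibition and lower numbers for stronger inhibition), compound 1 shows the highest number of the three, though compound 2 lies within the scatter of it. Compound 3 lies beyond the scatter, with a lower number. Compound 4 `O=C([C@@H]1C[C@H](N2CCN(c3ccc(Cl)cc3)CC2)CN1)N1CCSC1` has not yet been measured in this assay. Among the compounds with values here, it is derived from compound 1 by a single change: chloro in place of methoxy on an aromatic carbon No step between measured compounds isolates this change, so its effect is not known from the series. The expected step in this assay from compound 1 to compound 4 is small, probably within the scatter, leaning if anything toward a lower number. The expected value of compound 4 is 11 nM, with a range from 4 nM to 30 nM. This corresponds to an expected step of a 1.5-fold lower number from compound 1 to compound 4 (0.19 log units; within the scatter).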

Compound 4, half-maximal inhibitory concentration: 10.3 nM
The estimate for compound 4 lay 1.1-fold (0.03 log units) above the measured number; the measured number falls inside the stated range.
By their numbers in this assay, from the lowest: compound 3; then compounds 2, 4 and 1 (each within the scatter of the next).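

In this assay, within the data shown here, exchanging 4-methoxyphenyl for 4-chlorophenyl gives a 1.6-fold lower number from compound 1 to compound 4 (0.22 log units; within the scatter), the first reading that isolates a single change at this position. On the aromatic carbon para to a large group, chloro can thus stand in place of methoxy without a shift beyond the scatter, even though the hydrogen-bond acceptor of methoxy is lost. Nothing at hand explains the step.

As far as these compounds go, what an amine or a carboxylic acid on this aromatic carbon would do remains open. So does whether any group here gives a step beyond the scatter.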